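The source may report more compounds than this note shows. Statements on the series, on what has been measured and on what is new or still open speak of the compounds shown alone.

Three compounds have been measured in a functional assay on K562 cells (Homo sapiens) for inhibition, read by MTT assay, with a stated time of 72 h; on this read-out higher numbers stand for weaker inhibition and lower numbers for stronger inhibition:

- compound 1 `CCOC(=O)C1=C(Nc2ccccc2)S/C(=C\c2ccc([N+](=O)[O-])c(O)c2)C1=O` gives 12700 nM
- compound 2 `CCOC(=O)C1=C(Nc2ccccc2)S/C(=C\c2cccc(C(=O)O)c2)C1=O` gives 16200 nM
- compound 3 `CCOC(=O)C1=C(Nc2ccccc2Br)S/C(=C\c2ccc[nH]2)C1=O` gives 36300 nM

Compound 3 stands at the highest of the three numbers, meaning the weakest inhibition of the set. The nearest to it is compound 2, whose number is lower by a gap beyond the scatter, and the furthest is compound 1, whose number is lower still, again beyond the scatter.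

Compound 4 `CCOC(=O)C1=C(Nc2cccc([N+](=O)[O-])c2)S/C(=C\c2ccc[nH]2)C1=O` is the compound not yet measured. Next to compound 3, it differs in one place: 3-nitrophenyl in place of 2-bromophenyl on an amine nitrogen. For the measured compounds named here, no two of the measured compounds differ from each other in a single place, so the data give no measured step from which the effect of this exchange could be read, and the three measured compounds differ from one another in more than one place at once.

With nothing to anchor the direction, the step from compound 3 to compound 4 is expected to be small, a 1.2-fold lower number from compound 3 to compound 4 (0.08 log units; within the scatter), and not clearly beyond the scatter either way. Compound 4 is therefore estimated at 30000 nM in this assay, within a range of 10000 nM to 90000 nM.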

Compound 4, half-maximal inhibitory concentration: 7200 nM
Beside the measured number, compound 4's estimate is 4.2-fold (0.62 log units) above it; the measured number lies below the stated range.
By their numbers in this assay, from the lowest: compounds 4, 1 and 2 (each within the scatter of the next, the first and the last beyond it); then compound 3.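

For the compounds shown here, the exchange of 2-bromophenyl for 3-nitrophenyl on the amine nitrogen gives the first single-place step in this assay, and it is a 5.0-fold lower number from compound 3 to compound 4 (0.70 log units; beyond the scatter). Going by these compounds alone, this shows that the group on this nitrogen can by itself shift the number while the rest of the compound stays the same, which the earlier compounds, differing from one another in more than one place, could not show. Nothing given here bears on why the number drops, so the step stands without an explanation.

The two groups differ in both substituent and its place on the phenyl ring, and the compounds shown do not separate these two changes. From the compounds shown here alone, how an amine or a carboxylic acid on that phenyl ring would compare remains open, as does whether the exchange gives a similar step with other groups elsewhere on the shared core.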